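Methoxy for chloro on the aryl thiazole

The source may hold more compounds than are shown below. What is called first, only, known or untested is meant among the compounds shown, and "the series" means these compounds.

Compound 3 `C=C(Br)C(=O)Nc1cccc(-c2cn3c(-c4ccc(Cl)cc4)csc3n2)c1` gives the lowest number of the three measured, 3000 nM in a functional assay on HeLa cells (Homo sapiens) for inhibition, read by cell counting, with a stated time of 4 days; on this read-out lower numbers stand for stronger inhibition and higher numbers for weaker inhibition. Compound 1 `C=C(Br)C(=O)Nc1cccc(-c2cn3c(-c4ccccc4)csc3n2)c1` gives 3400 nM, and the step of a 1.1-fold lower number from compound 1 to compound 3 (0.05 log units; within the scatter) lies within the scatter. Compound 2 `COc1ccc(-c2csc3nc(-c4cccc(N)c4)cn23)cc1` carries an amine where compounds 1 and 3 carry the bromoacrylamide. In this assay compound 2 gives 19000 nM. Compound 4 `C=C(Br)C(=O)Nc1cccc(-c2cn3c(-c4ccc(OC)cc4)csc3n2)c1` differs from compound 3 by methoxy in place of chloro on an aromatic carbon. Among the compounds with values here, only the step from compound 1 to compound 3 bears on this position, and it was flat; compound 2 carries a methoxy but differs elsewhere as well, so its value gives no isolated reading. No change beyond the scatter is therefore expected, and the expected step is a 1.2-fold higher number from compound 3 to compound 4 (0.07 log units; within the scatter). Compound 4 is estimated at 3500 nM, with a range from 1500 nM to 8500 nM.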

Compound 4, half-maximal inhibitory concentration: 860 nM
Estimate against measurement, compound 4: 4.1-fold (0.61 log units) above, outside the stated range (below it).
By their numbers in this assay, from the lowest: compound 4; then compounds 3 and 1 (each within the scatter of the next); then compound 2.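

Chloro and hydrogen read alike at this position, but methoxy does not: in this assay replacing chloro gives a 3.5-fold lower number from compound 3 to compound 4 (0.54 log units; beyond the scatter) and replacing hydrogen gives a 4.0-fold lower number from compound 1 to compound 4 (0.60 log units; beyond the scatter) on the same core. The position para to a large group therefore responds to the choice of substituent, at least for methoxy. With the 4-methoxyphenyl held constant, adding the (1-bromoethenyl)carbonyl to the nitrogen gives a 22-fold lower number from compound 2 to compound 4 (1.34 log units; beyond the scatter) and so shows the size of that group's contribution in this pair.

No supporting data account for the methoxy step. Going by these compounds, whether ethoxy, hydroxy or a dimethylamino group at this position would follow methoxy remains open.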